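The source may hold more compounds than are shown below. What is called first, only, known or untested is meant among the compounds shown, and "the series" means these compounds.

In a functional assay on HCC827 cells (Homo sapiens) for inhibition, read by fluorescence, with a stated time of 72 h (on this read-out lower numbers stand for stronger inhibition of growth and higher numbers for weaker inhibition of growth), compound 1 (`COc1ccc(Nc2nc(N[C@H]3CC[C@H](N)CC3)nc3c2ncn3CCC(C)C)c(OC)c1`) gives 32900 nM. Compound 2 (`COc1ccc(Cn2cnc3c(Nc4cccc(Cl)c4)nc(N[C@H]4CC[C@H](N)CC4)nc32)cc1`) gives 18700 nM, within the scatter of that number, while compound 3 (`CC(C)=CCn1cnc2c(Nc3cccc(Cl)c3)nc(N[C@H]3CC[C@H](N)CC3)nc21`) gives 13500 nM, lower than compound 1 by more than the scatter. Compound 4 (`CC(C)CCn1cnc2c(NCc3cccc(Cl)c3)nc(N[C@H]3CC[C@H](N)CC3)nc21`) departs from compound 1 as follows: 3-chlorobenzyl in place of 2,4-dimethoxyphenyl on a nitrogen on an aromatic ring. For the measured compounds named here, the only measured step, a 1.4-fold lower number from compound 2 to compound 3 (0.14 log units; within the scatter), lies elsewhere on the molecule, so it does not measure this change directly. Going by the values given here, with no step measured at this nitrogen, no shift beyond the scatter is expected in this assay, with only a weak lean towards a lower number. The expected step is a 1.8-fold lower number from compound 1 to compound 4 (0.26 log units; within the scatter). For compound 4 the estimate is 18000 nM, with an expected range of 6000 nM to 45000 nM.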

Compound 4, concentration for 50% growth inhibition: 16700 nM
Estimate against measurement, compound 4: 1.1-fold (0.03 log units) above; the range from low to high includes it.
By their numbers in this assay, from the lowest: compounds 3, 4, 2 and 1 (each within the scatter of the next, the first and the last beyond it).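

At the nitrogen on an aromatic ring, a 2.0-fold lower number from compound 1 to compound 4 (0.29 log units; within the scatter) in this assay stays within the scatter, so this position accepts 3-chlorobenzyl in place of 2,4-dimethoxyphenyl without a clear shift in growth inhibition. For the compounds shown here, this is the first step read at this position, and the earlier step lay elsewhere on the molecule. No measurement available here accounts for the result. The change swaps the ring substituents and adds a carbon link together, leaving their separate contributions unresolved. From the compounds shown here alone, whether an amine, a carboxylic acid or a longer chain at this nitrogen would move the number also remains open.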